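The source may hold more compounds than are shown below. What is called first, only, known or untested is meant among the compounds shown, and "the series" means these compounds.

Measured compounds:
compound 1 `Cc1ccccc1-n1cc(-c2cccc(NS(=O)(=O)c3c[nH]c(=O)[nH]c3=O)c2)nn1` gives 9570 nM.
compound 2 `O=c1[nH]cc(S(=O)(=O)Nc2cccc(-c3cn(-c4ccccc4F)nn3)c2)c(=O)[nH]1` gives 13900 nM.
compound 3 `O=c1[nH]cc(S(=O)(=O)Nc2cccc(-c3cn(-c4cccc(F)c4)nn3)c2)c(=O)[nH]1` gives > 20000 nM.

In a functional assay on HepG2 cells (Homo sapiens) for antiproliferative activity, read by MTT assay, with a stated time of 24 h (on this read-out higher numbers stand for weaker inhibition and lower numbers for stronger inhibition), the values of compound 1 and compound 2 differ by a 1.5-fold higher number from compound 1 to compound 2 (0.16 log units; within the scatter). For compound 3 the assay returns only a limit, > 20000 nM, not a number; it sits at the limit of > 20000 nM in this assay, at which 1 of the 3 values shown sits. The steps of an at least 2.0-fold higher number from compound 1 to compound 3 (0.32 log units; beyond the scatter) and an at least 1.4-fold higher number from compound 2 to compound 3 (0.15 log units; that floor lies within the scatter) both point toward weaker inhibition, the first beyond the scatter, the second not clearly.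

Compound 4 `O=c1[nH]cc(S(=O)(=O)Nc2cccc(-c3cn(-c4ccc(Cl)cc4)nn3)c2)c(=O)[nH]1` differs from compound 3 by 4-chlorophenyl in place of 3-fluorophenyl on an aromatic nitrogen. Among the compounds with values here, the only measured step that moves a halogen around this ring, an at least 1.4-fold higher number from compound 2 to compound 3 (0.15 log units; that floor lies within the scatter), stayed near the scatter, so no clear shift is expected: a number no higher from compound 3 to compound 4 (the limit leaves the size open). Compound 4 is therefore estimated at 20000 nM, within 8000 nM to 45000 nM, with a fair chance that only a limit is reported again.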

Compound 4, half-maximal inhibitory concentration: 1960 nM
Estimate against measurement, compound 4: 10-fold (1.01 log units) above; measured number outside the range, below it.
By their numbers in this assay, from the lowest: compound 4; then compounds 1 and 2 (each within the scatter of the next). At a limit, above all of these: compound 3.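

Within the data shown here, on this aromatic nitrogen, the choice of aryl group matters more than the earlier compounds showed: in this assay, 4-chlorophenyl gives a 4.9-fold lower number from compound 1 to compound 4 (0.69 log units; beyond the scatter) and a 7.1-fold lower number from compound 2 to compound 4 (0.85 log units; beyond the scatter). Against 3-fluorophenyl it gives an at least 10-fold lower number from compound 3 to compound 4 (1.00 log units; beyond the scatter). That last step is only a floor, as compound 3 has a limit and not a number: the limit of > 20000 nM in this assay, at which 1 of the 4 values shown sits.

Chlorine and its place on the ring change together here, so the compounds shown leave open which of the two carries the effect. On these data alone, how 4-fluorophenyl, 3-chlorophenyl or 4-methoxyphenyl would behave also stays open.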